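A fluorine swap at the end of compound 3

The compounds below may be only part of what the source reports. "The series", "measured", "known", "first", "only" and "open" are said of these compounds alone.

Compounds measured in a functional assay on A549 cells (Homo sapiens) for inhibition, read by MTT assay, with a stated time of 72 h; on this read-out higher numbers stand for weaker inhibition and lower numbers for stronger inhibition:
Compound 1 `CCc1nc2c(C)cc(-c3ccc(CN4CCC(O)CC4)cc3)cn2c1NC(=O)OCc1cc(Cl)cc(Cl)c1`: "nd" (no result reported) (no result reported)
Compound 2 `CCc1nc2c(C)cc(-c3ccc(CN4CCN(C)CC4)cc3)cn2c1NC(=O)OCc1cc(Cl)cc(Cl)c1`: 4020 nM
Compound 3 `CCc1nc2c(C)cc(-c3ccc(CN4CCN(C)CC4)cc3)cn2c1NC(=O)OCc1ccc(C(F)(F)F)cc1`: > 20000 nM (a limit, not a number)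

Compound 3 stands at the limit of > 20000 nM in this assay, at which 1 of the 3 values shown sits, so compound 3 has only a limit and no exact number in this assay.

Compound 4 `CCc1nc2c(C)cc(-c3ccc(CN4CCN(C)CC4)cc3)cn2c1NC(=O)OCc1ccc(F)c(F)c1`, not yet measured, differs from compound 3 in one place: 3,4-difluorophenyl in place of 4-(trifluoromethyl)phenyl on a saturated chain carbon bound to an oxygen next to a carbonyl group. Here 3,4-difluorophenyl stands in place of 4-(trifluoromethyl)phenyl on a saturated chain carbon bound to an oxygen next to a carbonyl group.

Among the compounds with values here, one measured step bears on this place: an at least 4.9-fold higher number from compound 2 to compound 3 (0.69 log units; beyond the scatter). That step brought in the same 4-(trifluoromethyl)phenyl group that compound 4 gives up, and it shows that the group at this place can move the number beyond the scatter. Within the data shown here, compound 2, with 3,5-dichlorophenyl, gives 4020 nM, the only firm number here. Among the measured compounds shown here, no measured compound carries 3,4-difluorophenyl, so the direction is uncertain. A modest move toward lower numbers is expected, although compound 4 may also end at a limit. The expected step is an at least 1.4-fold lower number from compound 3 to compound 4 (0.15 log units; that floor lies within the scatter). Compound 4 is expected at 14000 nM, with an estimated range of 5000 nM to 35000 nM.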

Compound 4, half-maximal inhibitory concentration: > 20000 nM
Compound 4 gave a limit, no number; the forecaster's own chance of this, stated with the estimate: 45%; middle value at least 1.4-fold (0.15 log units) away from the limit.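

With an at least 4.9-fold higher number from compound 2 to compound 4 (0.69 log units; beyond the scatter), a second replacement for the 3,5-dichlorophenyl of compound 2 now moves the number beyond the scatter, so the change seen with 4-(trifluoromethyl)phenyl is not confined to that one group. In this assay compound 4 gives > 20000 nM, which is a limit of the assay and not a number, and the step between compound 3 and compound 4 cannot be read. Of the compounds with a reported result that differ only on the saturated chain carbon bound to an oxygen next to a carbonyl group, compound 2 alone keeps an exact number, and the two fluorine-bearing compounds share one limit: the limit of > 20000 nM in this assay, at which 2 of the 4 values shown sit.

As far as these compounds go, how far compound 3 and compound 4 lie past that limit, and whether they differ from each other, stays open. From the compounds shown here alone, it is also open whether the chlorine atoms themselves matter at this place, which a 3,5-difluorophenyl, a 3,5-dimethylphenyl or an unsubstituted phenyl group in the same place could help to show.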